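Dropping a Phenyl Group: Effect on Receptor Binding

The compounds below may be only part of what the source reports. "The series", "measured", "known", "first", "only" and "open" are said of these compounds alone.

Measured compounds:
compound 1 `Cc1cccc(O[C@@H]2CC[C@@H](C)N(C(=O)c3ccccc3-n3nccn3)C2)n1`, 12 nM
compound 2 `C[C@@H]1CC[C@@H](Oc2cc(-c3ccccc3)ccn2)CN1C(=O)c1ccccc1-n1nccn1`, 360 nM

In an assay on CHO-K1 cells for displacement of a labelled ligand from Orexin/Hypocretin receptor type 1 (Homo sapiens), read by radioligand binding (a higher number here means a weaker inhibitor, a lower number a stronger inhibitor), compound 1 gives 12 nM and compound 2 gives 360 nM. Compound 2 thus has the higher of the two numbers, and its gap to compound 1 lies beyond the usual scatter. Compound 3 `C[C@@H]1CC[C@@H](Oc2ccccn2)CN1C(=O)c1ccccc1-n1nccn1` keeps the shared core of compound 2 but differs in one place: hydrogen in place of phenyl on an aromatic carbon. For the measured compounds named here, no measured pair shows this exact change. Removing the phenyl is expected to lower the number, so the expected step is a 9.0-fold lower number from compound 2 to compound 3 (0.95 log units; beyond the scatter), beyond the scatter. Compound 3 is estimated at 40 nM, within a range from 10 nM to 160 nM.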

Compound 3, inhibition constant: 14000 nM
Beside the measured number, compound 3's estimate is 350-fold (2.54 log units) below it, and the stated range ends below it.
By their numbers in this assay, from the lowest: compound 1; then compound 2; then compound 3.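

Taking the phenyl off the aromatic carbon opposite the ring nitrogen does not free up binding in this assay but weakens it (a 39-fold higher number from compound 2 to compound 3 (1.59 log units; beyond the scatter)), so the unsubstituted ring is the poor case here. Hydrogen in place of methyl on an aromatic carbon also weakens it sharply (a 1200-fold higher number from compound 1 to compound 3 (3.07 log units; beyond the scatter)), so a methyl alone can decide much of the binding. No supporting data explain either loss. From the compounds shown here alone, whether an ethyl, a methoxy group or a chlorine atom on that carbon would restore binding stays open.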